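A Chloro Substituent Replacing the Amide on the Alkyne Arm

This account rests on a few compounds, and the source may have more. Where it says the series, first, only, none or still open, it means among the compounds named here.

Of the compounds shown here, two built on a shared core have so far been measured in an assay on CHO cells for displacement of a labelled ligand from prostaglandin D2 receptor 2 (Homo sapiens), read by scintillation counting; a higher number here means a weaker inhibitor, a lower number a stronger inhibitor. Compound 1 `CN(C)C(=O)c1ccc(C#Cc2cc(Cl)ccc2OCC(=O)O)cc1` gives 55 nM in this assay. Compound 2 `Cc1ccc(S(=O)(=O)N(C)C(C)C)cc1C#Cc1cc(Cl)ccc1OCC(=O)O` gives 3.8 nM in this assay. Of these two numbers, compound 1 holds the higher one, and its gap to compound 2 lies beyond the scatter, so compound 1 is the weaker binder of the pair.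

Compound 3 `O=C(O)COc1ccc(Cl)cc1C#Cc1ccc(Cl)cc1` is the next to be examined. It differs from compound 1 by chloro in place of dimethylcarbamoyl on an aromatic carbon: the dimethylcarbamoyl leaves and a chloro enters on an aromatic carbon para to a large group. No such exchange has yet been measured among these compounds, so the expectation rests on the numbers for compound 1 and compound 2 alone. In this assay the expected step is a 2.0-fold higher number from compound 1 to compound 3 (0.30 log units; within the scatter), a move toward a higher number that stays close to the edge of the scatter. Compound 3 is therefore estimated to give about 110 nM in this assay, with a range from 30 nM to 400 nM.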

Compound 3, inhibition constant: 60 nM
The estimate for compound 3 lay 1.8-fold (0.26 log units) above the measured number, and the stated range covers the measured number.
By their numbers in this assay, from the lowest: compound 2; then compounds 1 and 3 (each within the scatter of the next).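

Placing chloro in place of dimethylcarbamoyl on this aromatic carbon, para to a large group, gives a 1.1-fold higher number from compound 1 to compound 3 (0.04 log units; within the scatter) in this assay, so the assay does not separate the two compounds. Five heavy atoms, including a double bond outside aromatic rings and a hydrogen-bond acceptor, leave here and a single chlorine enters, yet the number stays within the scatter; for this pair, then, the dimethylcarbamoyl is not needed to keep the binding seen for compound 1. No measurement among the data shown bears on why these two groups read alike.

On these data alone, whether this tolerance extends to other groups on the same carbon stays open, for instance a bare hydrogen, a fluoro, a methoxy, an amine or a carboxylic acid, and the two compounds alone cannot say how far it reaches. Compound 2 differs from compound 1 and compound 3 in more than one place, so what separates its number from theirs cannot be assigned to any single group, and the sulfonamide and the methyl it carries remain to be judged apart.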